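The compounds below may be only part of what the source reports. "The series", "measured", "known", "first", "only" and "open" are said of these compounds alone.

Measured so far:
compound 1, `CCOC(=O)c1cccc(-c2ccc(O)cc2)c1`: 77%
compound 2, `CCOC(=O)c1cccc(-c2ccc(OCC)nc2)c1`: 68%

Of the compounds shown here, two have been tested in an assay on COS-7 cells for inhibition of patatin-like phospholipase domain-containing protein 2 (Mus musculus), tested at 200 uM (on this read-out higher numbers stand for more inhibition at the one concentration tested (going by the name of the read-out) and lower numbers for less inhibition), and in this assay compound 1 gives 77% while compound 2 gives 68%. These two numbers sit within the usual scatter of each other, so neither compound can be told apart from the other on this read-out; compound 1 simply carries the larger of the two figures without being separable from compound 2.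

The next compound, compound 3, `CCOC(=O)c1cccc(-c2ccc(CN3CCCC3)cc2)c1`, differs from compound 1 in one spot: (pyrrolidin-1-yl)methyl in place of hydroxy on an aromatic carbon. For the measured compounds named here, no step between two measured compounds resembles this change, so there is no measured precedent to lean on. Given that compound 1 gives 77%, the expectation is a step downward beyond the scatter, a number 22 percentage points lower from compound 1 to compound 3 (beyond the scatter), with wide uncertainty. Compound 3 is therefore estimated at 55%, in a range from 20% to 85%.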

Compound 3, a percentage reported as inhibition, at one concentration (the size of the read-out at that concentration, not a potency): 33%
Estimate against measurement, compound 3: 22 percentage points above, and the stated range covers the measured number.
By their numbers in this assay, from the lowest: compound 3; then compounds 2 and 1 (each within the scatter of the next).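

For the compounds shown here, this is the first measured change at this position, and in this assay the swap of hydroxy for (pyrrolidin-1-yl)methyl, on an aromatic carbon para to a large group, comes with a number 44 percentage points lower from compound 1 to compound 3 (beyond the scatter). The read-out therefore responds to what sits at this spot on the shared core, and this particular replacement retains clearly less inhibition at the one concentration tested. Nothing available explains why the number falls.

Going by these compounds alone, the single step removes hydroxy and brings in the pyrrolidine ring together, leaving it open whether the loss of the first or the arrival of the second goes with the drop. Methoxy, aminomethyl or a carboxylic acid at the same spot would help separate those two possibilities.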